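The compounds below may be only part of what the source reports. "The series", "measured", "known", "first", "only" and "open" are said of these compounds alone.

Two compounds have been measured in a functional assay on the whole organism (strain Swiss) with Mus musculus as the target, in the maximal electroshock model, with a stated time of 0.25 h, at a dose of 300 mg/kg by the intraperitoneal route; on this read-out lower numbers stand for a weaker effect and higher numbers for a stronger effect at the one dose given:

Compound 1 `CCC(C(=O)N1CCN(c2cccc(OC)c2)CC1)N1C(=O)CCC1=O` gives 25%.
Compound 2 `CCC(C(=O)N1CCN(c2ccc(F)cc2)CC1)N1C(=O)CCC1=O` gives 0%.

Going by the values given here, compound 2 therefore stands lowest of the two numbers; its only neighbour is compound 1, and the single measured step, a number 25 percentage points lower from compound 1 to compound 2 (beyond the scatter), lies beyond the scatter. Compound 3 `CCC(C(=O)N1CCN(c2cccc(Cl)c2)CC1)N1C(=O)CCC1=O` has not yet been measured. It differs from compound 2 in one place: 3-chlorophenyl in place of 4-fluorophenyl on an amine nitrogen in a ring. Among the compounds with values here, only one measured step bears on this change. That step, a number 25 percentage points lower from compound 1 to compound 2 (beyond the scatter), exchanged the group on the same amine nitrogen in a ring and was modest in size; it shows that the group on this nitrogen matters, but neither measured compound carries a 3-chlorophenyl, so the direction for compound 3 cannot be read directly. Since compound 1 with its 3-methoxyphenyl gave 25%, a partial return toward that level seems the more likely outcome, with a wide range. Compound 3 is expected to give 15%, within 0% to 40%. This corresponds to an expected step of a number 15 percentage points higher from compound 2 to compound 3 (beyond the scatter).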

Compound 3, a percentage reported as activity, at one dose (the size of the read-out at that dose, not a potency): 75%
For compound 3 the middle estimate is 60 percentage points below the measured one; the whole stated range lies below it.
By their numbers in this assay, from the lowest: compound 2; then compound 1; then compound 3.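

In this assay, the group on the amine nitrogen in the ring can move the read-out much further than the first pair showed: the change from 4-fluorophenyl to 3-chlorophenyl gives a number 75 percentage points higher from compound 2 to compound 3 (beyond the scatter) and is large, and it also reverses the direction of the earlier, modest step. Going by these compounds alone, the narrower comparison gives a number 50 percentage points higher from compound 1 to compound 3 (beyond the scatter) for chloro in place of methoxy on an aromatic carbon, so the group on the aromatic ring matters even when only that one group differs. The 4-fluorophenyl and 3-chlorophenyl groups have the same heavy-atom count and no hydrogen-bond donors or acceptors, so those counts do not separate them, and nothing measured here explains the differences.

The step between the fluorine and chlorine compounds changes both the halogen and the number in the group's name, so 3-fluorophenyl and 4-chlorophenyl groups would be needed to tell these two changes apart. From the compounds shown here alone, it also remains open whether chlorine itself is special or whether a 3-methylphenyl group or a plain phenyl group on the same nitrogen would give a similar number.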